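This account rests on a few compounds, and the source may have more. Where it says the series, first, only, none or still open, it means among the compounds named here.

Three analogues have been tested in a functional assay on OVCAR-8 cells (Homo sapiens) for inhibition; on this read-out lower numbers stand for stronger inhibition of growth and higher numbers for weaker inhibition of growth. Compound 3 `COc1ccc(-c2cn(-c3cccc(C(=O)/C=C/c4cc(OC)c(OC)c(OC)c4)c3)c(=O)[nH]2)cc1` gives 2530 nM, compound 1 `COc1cc(/C=C/C(=O)c2cccc(-n3cc(-c4ccc(Cl)cc4)[nH]c3=O)c2)cc(OC)c1OC` gives 3850 nM, and compound 2 `COc1ccc(-c2cn(-c3cccc(C(=O)/C=C/c4ccc(O)c(OC)c4)c3)c(=O)[nH]2)cc1` gives 4970 nM. Compound 2 differs from compound 3 in its core by 4-hydroxy-3-methoxyphenyl in place of 3,4,5-trimethoxyphenyl on a double-bonded chain carbon bound to a double-bonded chain carbon, a step of a 2.0-fold lower number from compound 2 to compound 3 (0.29 log units; within the scatter). Compound 1 differs from compound 3 by chloro in place of methoxy on an aromatic carbon, which made a step of a 1.5-fold higher number from compound 3 to compound 1 (0.18 log units; within the scatter). Compound 4 `COc1cc(/C=C/C(=O)c2cccc(-n3cc(-c4ccc(Cl)cc4)[nH]c3=O)c2)ccc1O`, not yet measured, carries the same change relative to compound 2, namely (chloro in place of methoxy on an aromatic carbon). The step from compound 2 to compound 4 is therefore expected to be a 1.4-fold higher number from compound 2 to compound 4 (0.15 log units; within the scatter) in this assay, resting on the step from compound 3 to compound 1 of a 1.5-fold higher number from compound 3 to compound 1 (0.18 log units; within the scatter). Compound 4 is estimated at 7000 nM, with a likely range from 3500 nM to 15000 nM.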

Compound 4, concentration for 50% growth inhibition: 4180 nM
Estimate against measurement, compound 4: 1.7-fold (0.22 log units) above; the measured number falls inside the stated range.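

In this assay, the change from 4-methoxyphenyl to 4-chlorophenyl gives a 1.2-fold lower number from compound 2 to compound 4 (0.08 log units; within the scatter). Set beside the earlier step, the change behaves alike on the two cores, with no difference that can be told apart: the same change on two cores in this assay, a 1.5-fold higher number (0.18 log units; within the scatter) from compound 3 to compound 1 and a 1.2-fold lower number (0.08 log units; within the scatter) from compound 2 to compound 4, 1.8-fold (0.26 log units) apart, within the scatter of two such steps This shows that, on these two cores, the change carries over without a measurable shift, but it gives the change no direction and says nothing about any core beyond these two.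

The compounds shown leave open what an amine or a carboxylic acid would do on that aromatic carbon in place of chloro or methoxy. They also leave open whether a longer chain, such as butoxy, would behave as methoxy does there.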